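This account rests on a few compounds, and the source may have more. Where it says the series, first, only, none or still open, it means among the compounds named here.

Measured in a functional assay on MCF7 cells (Homo sapiens) for inhibition, read by sulforhodamine B assay, with a stated time of 48 h, tested at 50 uM; a lower number here means less inhibition of growth, a higher number more inhibition of growth at the concentration tested:
compound 1 `COc1ccc([C@@H]2C/C(=N/OCc3cn(-c4ccc(O)cc4)nn3)c3cc(CC=C(C)C)c(OC)cc3O2)cc1`: 63%
compound 2 `COc1cc2c(cc1CC=C(C)C)C(=O)C[C@@H](c1ccc(Oc3ccc(F)cc3)cc1)O2`: 37%

Compound 2, at 37%, is the lower of the two. Compound 1 gives 63%, and the gap between the two lies beyond the scatter. Compound 3 `C#CCOc1ccc([C@@H]2CC(=O)c3cc(CC=C(C)C)c(OC)cc3O2)cc1` has not yet been measured in this assay. It keeps the core of compound 2 and carries propargyl in place of 4-fluorophenyl on an oxygen on an aromatic ring. Going by the values given here, no measured pair differs in one place, so nothing calibrates this change and the expectation is weak. A step within the scatter is expected, with no firm direction, taking compound 2 at 37% as the starting point. The expected step is a number 3 percentage points higher from compound 2 to compound 3 (within the scatter). For compound 3 the estimated value is 40%, with an expected range of 22% to 60%.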

Compound 3, percent growth inhibition at one concentration: 68%
Beside the measured number, compound 3's estimate is 28 percentage points below it, outside the stated range (above it).
By their numbers in this assay, from the lowest: compound 2; then compounds 1 and 3 (each within the scatter of the next).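

In this assay, going by these compounds alone, the substituent on this oxygen matters, and the step of a number 31 percentage points higher from compound 2 to compound 3 (beyond the scatter) is the first that can be read at a single place. The change removes 4-fluorophenyl, with its six-membered aromatic ring, and brings in propargyl, which has no ring and fewer heavy atoms, so an aryl group on this oxygen is not required for this level of growth inhibition at the concentration tested. No measurement at hand bears on the reason for the step.

With one pair, the loss of the aromatic ring cannot be separated from the arrival of the triple bond, since both change together. On these data alone, whether a saturated propyl chain, a plain methyl group or a 2-aminoethyl chain on this oxygen would hold the same level remains open.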